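A few compounds are considered here, and "the series" means these few. Any claim that something is new, unique, unknown or untested is made for them only; others in the source may bear on it.

Among the measured compounds shown here, compound 2 `CNC(=O)c1cc(Oc2ccc(/C=C/c3ccncc3)cc2)ccn1` is one of two compounds measured in a functional assay on A549 cells (Homo sapiens) for antiproliferative activity, read by CCK-8 assay, with a stated time of 48 h (a lower number here means a stronger inhibitor, a higher number a weaker inhibitor), where compound 2 gives 13200 nM. For the measured compounds named here, its only neighbour is compound 1 `CNC(=O)c1cc(Oc2ccc(/C=C/c3ccccn3)cc2)ccn1`, which in this assay gives 17400 nM. Going by the values given here, the single measured step, a 1.3-fold lower number from compound 1 to compound 2 (0.12 log units; within the scatter), concerns the pyridine ring on the double-bonded chain and lies within the scatter, so the two numbers cannot be told apart and neither compound can be called the stronger.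

Compound 3 `COc1ccc(NC(=O)c2cc(Oc3ccc(/C=C/c4ccncc4)cc3)ccn2)cc1` is not yet measured. It differs from compound 2 at the amide-type nitrogen: 4-methoxyphenyl in place of methyl on an amide-type nitrogen. Among the compounds with values here, no measured step touches this position; the one step on record changes a different part of the molecule and was itself within the scatter. There is therefore nothing in the measured pairs that points to a direction or a size for the change from methylamino to (4-methoxyphenyl)amino.

With no guidance from the data, the number for compound 3 is expected to stay near that of compound 2, with a wide range: the expected step is a 1.2-fold lower number from compound 2 to compound 3 (0.08 log units; within the scatter). The estimate for compound 3 is 11000 nM, between 2500 nM and 45000 nM.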

Compound 3, half-maximal inhibitory concentration: 25600 nM
Estimate against measurement, compound 3: 2.3-fold (0.37 log units) below; the measured number falls inside the stated range.
By their numbers in this assay, from the lowest: compounds 2, 1 and 3 (each within the scatter of the next).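

Among the compounds shown here, this is the first measured step at the amide-type nitrogen, and in this assay the change to 4-methoxyphenyl in place of methyl reads as a 1.9-fold higher number from compound 2 to compound 3 (0.29 log units; within the scatter), which leaves compound 2 and compound 3 impossible to tell apart. The position therefore carries either a methyl of 1 heavy atom or a 4-methoxyphenyl of 8 heavy atoms, with its six-membered aromatic ring and hydrogen-bond acceptor, and this assay shows no difference beyond the scatter between the two. No measured information bears on why the two numbers lie so close.

The compounds shown leave open whether any other group on this nitrogen, such as a plain phenyl, a longer alkyl chain, a carboxylic acid or an amine, would move the number beyond the scatter, so the limits of what the position accepts remain undefined. They also leave open whether 4-methoxyphenyl on the amide-type nitrogen would read the same with pyridin-2-yl on the double-bonded chain, the ring carried by compound 1.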